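Adding a 2-methoxyethyl group to compound 3

This account rests on a few compounds, and the source may have more. Where it says the series, first, only, none or still open, it means among the compounds named here.

In an ADME assay on RAW264.7 cells (Mus musculus) for cytotoxicity, read by MTT assay, with a stated time of 24 h (on this read-out higher numbers stand for lower toxicity in this test and lower numbers for higher toxicity in this test), compound 1 `CC/C=C\C[C@H]1C(=O)C=C[C@H]1CC(=O)OCC` gives 146 uM and compound 2 `CC/C=C\C[C@H]1C(=O)C=C[C@H]1CC(=O)Oc1ccc(O)cc1` gives 49 uM while compound 3 `CC/C=C\C[C@H]1C(=O)C=C[C@H]1CC(=O)OCCO` gives 161 uM on the same scale. Two steps place that last value: a 1.1-fold higher number from compound 1 to compound 3 (0.04 log units; within the scatter) stays within the scatter, and a 3.3-fold higher number from compound 2 to compound 3 (0.52 log units; beyond the scatter) goes beyond it. Among the compounds with values here, compound 4 `CC/C=C\C[C@H]1C(=O)C=C[C@H]1CC(=O)OCCOCCOC` has 2-methoxyethyl in place of hydrogen on an oxygen on a saturated carbon and no measured step matches this change. Among the measured compounds only compound 2, with its 4-hydroxyphenyl group, stands apart, with a 3.0-fold lower number from compound 1 to compound 2 (0.47 log units; beyond the scatter) as the modest step, and compound 4 has no such ring. So no step beyond the scatter is expected, and the estimated change is a 1.2-fold lower number from compound 3 to compound 4 (0.06 log units; within the scatter) overall. For compound 4 the expected value is 140 uM (estimated range 70 uM to 270 uM).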

Compound 4, half-maximal toxic concentration: 161 uM
Compound 4: the middle estimate sits 1.2-fold (0.06 log units) below what was measured; the measured number falls inside the stated range.
By their numbers in this assay, from the lowest: compound 2; then compounds 1, 3 and 4 (each within the scatter of the next).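

In this assay, 2-methoxyethyl in place of hydrogen on the oxygen of compound 3 gives no change at the digits printed from compound 3 to compound 4 (within the scatter), so this position takes the added chain with no step beyond the scatter. The comparison with the ethyl group reads the same, with a 1.1-fold higher number from compound 1 to compound 4 (0.04 log units; within the scatter). With the 4-hydroxyphenyl group replaced, the step is a 3.3-fold higher number from compound 2 to compound 4 (0.52 log units; beyond the scatter), which leaves compound 2 as the only one of the four set apart.

Nothing available explains this flat result. The compounds shown leave open whether an amine or a carboxylic acid on this chain, or a still longer chain, would move the number.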